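Taking the bromo off compound 3

The source may hold more compounds than are shown below. What is called first, only, known or untested is meant among the compounds shown, and "the series" means these compounds.

Measured so far in a functional assay on HeLa cells (Homo sapiens) for antiproliferative activity, read by MTT assay, with a stated time of 48 h (on this read-out higher numbers stand for weaker inhibition and lower numbers for stronger inhibition), are three compounds
Compound 1 `Fc1cccc(F)c1CSc1nnc(-c2cnccn2)o1` with > 50000 nM as a limit
Compound 2 `Clc1ccc(CSc2nnc(-c3cnccn3)s2)cc1` with 18900 nM as a number
Compound 3 `Brc1cccc(CSc2nnc(-c3cnccn3)n2-c2ccccc2)c1` with 9580 nM as a number

The entry for compound 1 is a limit and not a number. That leaves two true numbers, and compound 3 at 9580 nM and compound 2 at 18900 nM lie within the usual scatter of each other, so neither can be ranked over the other.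

The next compound is compound 4 `c1ccc(CSc2nnc(-c3cnccn3)n2-c2ccccc2)cc1`, where hydrogen stands in place of bromo on an aromatic carbon hydrogen in place of bromo on an aromatic carbon and 3-bromobenzyl thus becomes benzyl. For the measured compounds named here, no two measured compounds differ in just one place, so no measured step gauges this change. Starting from compound 3 at 9580 nM in this assay, a small move towards weaker inhibition is expected, perhaps no larger than the scatter. The estimated change is a 1.7-fold higher number from compound 3 to compound 4 (0.22 log units; within the scatter) and remains a cautious expectation. For compound 4 the expected value is 16000 nM within an estimated range from 6500 nM to 40000 nM for the measurement to come.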

Compound 4, half-maximal inhibitory concentration: 35600 nM
Estimate against measurement, compound 4: 2.2-fold (0.35 log units) below; the measured number falls inside the stated range.
By their numbers in this assay, from the lowest: compounds 3, 2 and 4 (each within the scatter of the next, the first and the last beyond it). At a limit, above all of these: compound 1.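

In this assay, for the compounds shown here, putting hydrogen in place of bromo gives a 3.7-fold higher number from compound 3 to compound 4 (0.57 log units; beyond the scatter), and this is the first comparison here of two compounds that differ in one place only. It shows that the bromo of the 3-bromobenzyl group makes a measurable, though modest, difference to inhibition in this series, since 3-bromobenzyl gives the lower number and plain benzyl the higher, with the step lying beyond the scatter. Compound 1 remains the one entry that is a limit and not a number: the limit of > 50000 nM in this assay, at which 1 of the 4 values shown sits.

Why the bromo matters cannot be read from these values, and one pair cannot show whether the difference is specific to bromine. A methoxy group or an amine on the same aromatic carbon would test that, and bromo at the other ring positions would show whether the place itself counts.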